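Moving the Methyl Around the Phenyl Ring

The source may hold more compounds than are shown below. What is called first, only, known or untested is meant among the compounds shown, and "the series" means these compounds.

Three compounds share one core and differ only in the aromatic group attached to it. Compound 1 `Cc1ccc(-c2ccccc2OC(C)C2=NCCN2)cc1` carries a 4-methylphenyl group; in a functional assay on CHO cells for agonist activity at Alpha-2C adrenergic receptor (Homo sapiens) (on this read-out lower numbers stand for smaller maximal responses and higher numbers for larger maximal responses), compound 1 gives 0.46. Compound 2 `CC(Oc1ccccc1-c1cccnc1)C1=NCCN1` carries a pyridin-3-yl group instead, and in this assay compound 2 gives 1. Compound 3 `Cc1ccccc1-c1ccccc1OC(C)C1=NCCN1` carries a 2-methylphenyl group; in this assay compound 3 gives 0.45. On these numbers compound 3 sits together with compound 1, since the step a number 0.010 lower from compound 1 to compound 3 (within the scatter), while both stand well apart from compound 2, as the step a number 0.55 lower from compound 2 to compound 3 (beyond the scatter) shows.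

The next compound, compound 4 `Cc1cccc(-c2ccccc2OC(C)C2=NCCN2)c1`, keeps the same atoms as compound 3 but joins them differently: 3-methylphenyl in place of 2-methylphenyl on an aromatic carbon.

Among the compounds with values here, the one measured step that bears on this change is the swap of one methylphenyl isomer for another, a number 0.010 lower from compound 1 to compound 3 (within the scatter), which stayed within the scatter. The large steps to and from compound 2 concern a different kind of group and do not bear on moving a methyl around a phenyl ring. On that basis no step beyond the scatter is expected in this assay, so a number 0.010 higher from compound 3 to compound 4 (within the scatter) is the expected outcome. Compound 4 is therefore estimated at 0.46, within a range from 0.33 to 0.6.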

Compound 4, intrinsic activity: the largest response reached, as a fraction of the reference agonist's: 0.6
For compound 4 the middle estimate is 0.14 below the measured one; low and high end bracket the measured number.
By their numbers in this assay, from the lowest: compounds 3 and 1 (each within the scatter of the next); then compound 4; then compound 2.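

Moving the methyl around the phenyl ring is not a neutral change in this assay: the 3-methylphenyl group stands apart from the 2-methylphenyl group (a number 0.15 higher from compound 3 to compound 4 (beyond the scatter)) and from the 4-methylphenyl group (a number 0.14 higher from compound 1 to compound 4 (beyond the scatter)), whereas the two earlier isomers showed no step beyond the scatter between them. Yet the change among methylphenyl isomers remains modest beside the change of aromatic group, since the pyridin-3-yl group still stands well clear of the 3-methylphenyl group (a number 0.40 lower from compound 2 to compound 4 (beyond the scatter)), and compound 2 keeps the largest maximal response of the four. No evidence is at hand to say why this one placing of the methyl differs from the other two.

On these data alone, what stays open is whether this order belongs to the methyl alone, or whether a chlorine, a methoxy group or a hydroxymethyl group carried on the phenyl ring would rank the three placings in the same way. As far as these compounds go, it is also open whether the high value of compound 2 is kept with a pyridin-2-yl or pyridin-4-yl group in place of the pyridin-3-yl group.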